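The source may hold more compounds than are shown below. What is called first, only, known or untested is meant among the compounds shown, and "the series" means these compounds.

Measured in an assay on membranes from Sf9 cells for displacement of a labelled ligand from histamine H2 receptor (Homo sapiens), read by scintillation counting, with a stated time of 60 min; a higher number here means a weaker inhibitor, a lower number a stronger inhibitor:
compound 1, `COc1ccc(C(C)NC(=O)/N=C(\N)NCCCc2sc(N)nc2C)cc1`, gives 37.2 nM;
compound 2, `Cc1nc(N)sc1CCCN/C(N)=N/C(=O)N[C@H](C)c1ccccc1`, gives 17.8 nM;
compound 3, `Cc1nc(N)sc1CCCN/C(N)=N/C(=O)NC1CCCCC1`, gives 170 nM.

Compound 3 stands highest of the three numbers in this assay, with compound 1 nearest to it and compound 2 furthest from it. The unmeasured compound 4, `Cc1nc(N)sc1CCCN/C(N)=N/C(=O)NC(C)c1ccco1`, differs from compound 3 by 1-(furan-2-yl)ethyl in place of cyclohexyl on an amide-type nitrogen; cut one bond further out, the same difference reads cyclohexylamino to (1-(furan-2-yl)ethyl)amino. Within the data shown here, one measured step bears on this change: a 9.6-fold higher number from compound 2 to compound 3 (0.98 log units; beyond the scatter). That step shows that the 1-phenylethyl group on this nitrogen gives a clearly lower number than cyclohexyl, and compound 1 also sits well below compound 3. Among the measured compounds shown here, compound 4 again carries an aromatic ring in place of the saturated one, though the furan-bearing group itself has no measured precedent here, and compound 4 is not a single enantiomer as compound 2 is. Compound 4 is therefore estimated at 40 nM, with a range of 15 nM to 110 nM. The step expected is a 4.3-fold lower number from compound 3 to compound 4 (0.63 log units; beyond the scatter), a decrease beyond the scatter.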

Compound 4, inhibition constant: 31.6 nM
Compound 4: middle estimate off by 1.3-fold (0.10 log units), on the high side; the measured number falls inside the stated range.
By their numbers in this assay, from the lowest: compounds 2, 4 and 1 (each within the scatter of the next, the first and the last beyond it); then compound 3.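

In this assay, among these compounds, 1-(furan-2-yl)ethyl in place of cyclohexyl on the amide-type nitrogen gives a 5.4-fold lower number from compound 3 to compound 4 (0.73 log units; beyond the scatter), so a lower number than with cyclohexyl is no longer seen only with a six-membered aromatic ring: a five-membered aromatic ring with a hetero atom gives one too. Among the aromatic groups, the exchanges cannot be told apart, with 1-(furan-2-yl)ethyl in place of 1-phenylethyl giving a 1.8-fold higher number from compound 2 to compound 4 (0.25 log units; within the scatter) and furan-2-yl in place of 4-methoxyphenyl giving a 1.2-fold lower number from compound 1 to compound 4 (0.07 log units; within the scatter). No measurement offered here accounts for these differences.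

Going by these compounds, it remains open whether a saturated tetrahydrofuran-2-yl ring would stay near compound 4 or return toward compound 3, and whether a furan-2-ylmethyl group, lacking the methyl on the chain carbon, would hold the number. On these data alone, the separate enantiomers of compound 4 also remain open.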